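Dropping the Bromine from Compound 2

The compounds below may be only part of what the source reports. "The series", "measured", "known", "first", "only" and "open" are said of these compounds alone.

Three compounds share one core: compound 1 `O=C1C(=Cc2ccc(O)cc2)C(=O)N(c2ccc(Cl)cc2)N1c1ccc(Cl)cc1`, compound 2 `O=C1C(=Cc2ccc(Br)cc2)C(=O)N(c2ccc(Cl)cc2)N1c1ccc(Cl)cc1` and compound 3 `O=C1C(=Cc2c[nH]c3ccccc23)C(=O)N(c2ccc(Cl)cc2)N1c1ccc(Cl)cc1`. In a functional assay on SMMC-7721 cells (Homo sapiens) for cytotoxicity, read by MTT assay, with a stated time of 72 h (a higher number here means a weaker inhibitor, a lower number a stronger inhibitor), compound 1 gives 20600 nM, compound 2 gives 16600 nM, and compound 3 gives 19600 nM. Compound 2 holds the lowest of the three numbers, yet the two steps joining it to the others, a 1.2-fold lower number from compound 1 to compound 2 (0.09 log units; within the scatter) and a 1.2-fold higher number from compound 2 to compound 3 (0.07 log units; within the scatter), both lie within the scatter, so no order can be claimed. Compound 4 `O=C1C(=Cc2ccccc2)C(=O)N(c2ccc(Cl)cc2)N1c1ccc(Cl)cc1` differs from compound 2 as follows: hydrogen in place of bromo on an aromatic carbon. Within the data shown here, the only step touching the same aromatic carbon, a 1.2-fold lower number from compound 1 to compound 2 (0.09 log units; within the scatter), stayed within the scatter, as did the wider swap a 1.2-fold higher number from compound 2 to compound 3 (0.07 log units; within the scatter). Compound 4 is therefore expected to show no step beyond the scatter, a 1.1-fold higher number from compound 2 to compound 4 (0.04 log units; within the scatter). Compound 4 is estimated at 18000 nM, within a range from 9000 nM to 36000 nM.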

Compound 4, half-maximal inhibitory concentration: 26200 nM
Compound 4: the middle estimate sits 1.5-fold (0.16 log units) below what was measured; measured number inside the range.
By their numbers in this assay, from the lowest: compounds 2, 3, 1 and 4 (each within the scatter of the next).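

With hydrogen on this aromatic carbon, the step from bromo reads a 1.6-fold higher number from compound 2 to compound 4 (0.20 log units; within the scatter) and the step from hydroxy reads a 1.3-fold higher number from compound 1 to compound 4 (0.10 log units; within the scatter), while replacing the whole indolyl group gives a 1.3-fold higher number from compound 3 to compound 4 (0.13 log units; within the scatter). Among these compounds, the bare phenyl thus adds the missing reference point: even with no substituent on this carbon, no step leaves the scatter, so neither bromo nor hydroxy can be said to matter here. No evidence is available that would explain these numbers.

Still open, on these data alone, is whether an amine or a carboxylic acid on this aromatic carbon would move the number beyond the scatter in this assay. As far as these compounds go, whether a change elsewhere on the shared core would do so also remains open.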